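The compounds below may be only part of what the source reports. "The series", "measured", "known", "first", "only" and "open" are said of these compounds alone.

Measured so far in a physicochemical assay for lipophilicity; a lower number here means a more polar compound, a higher number a more lipophilic compound:
- compound 1 `CS(=O)(=O)Cc1cc(C2=CCOCC2)nc(-c2cccc(O)c2)n1` gives 3.3
- compound 2 `Oc1cccc(-c2nccc(C3=CCOCC3)n2)c1` gives 3.6
- compound 3 `CNCC(=O)Nc1ccc(-c2nc(CS(C)(=O)=O)cc([C@]34CCOC[C@H]3C4)n2)cc1` gives 3.1

Compound 1 lies within the usual scatter of both compound 2 and compound 3, so these numbers cannot rank it against either one. Still unmeasured is compound 4 `CS(=O)(=O)Cc1cc([C@@]23CCOC[C@@H]2C3)nc(-c2cccc(O)c2)n1`, which keeps the core of compound 1 and alters one group, on an aromatic carbon next to the ring nitrogen. The change is a group of 7 heavy atoms (6 carbon, 1 oxygen; one three-membered non-aromatic ring of carbon only, one six-membered non-aromatic ring with 1 hetero atom) in place of a group of 6 heavy atoms (5 carbon, 1 oxygen; one six-membered non-aromatic ring with 1 hetero atom), on an aromatic carbon. A double bond outside aromatic rings leaves, and a three-membered ring of carbon only enters.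

Among the compounds with values here, no measured pair isolates this swap. Within the data shown here, the one measured step, a number 0.30 log units higher from compound 1 to compound 2 (within the scatter), concerns a different place on the core, so it is only a loose guide to how large a single change can be. Compound 3 carries the same pair of rings and gives 3.1, but it also differs from compound 1 elsewhere, so no clean step can be read from it. Among the measured compounds shown here, with only that evidence, the expected result in this assay is a number 0.10 log units higher from compound 1 to compound 4 (within the scatter), which is no step beyond the scatter. For compound 4 the estimated value is 3.4, with an expected range from 3 to 3.8.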

Compound 4, partition coefficient: 3.7
Estimate against measurement, compound 4: 0.30 log units below; low and high end bracket the measured number.
By their numbers in this assay, from the lowest: compounds 3, 1, 2 and 4 (each within the scatter of the next, the first and the last beyond it).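

In this assay, putting the group with a three-membered ring of carbon only in place of the group with a double bond outside aromatic rings, on an aromatic carbon next to the ring nitrogen, gives a number 0.40 log units higher from compound 1 to compound 4 (beyond the scatter). This is the first single change shown in the series that lies beyond the usual scatter, whereas removing the (methylsulfonyl)methyl group elsewhere on the shared core gives a number 0.30 log units higher from compound 1 to compound 2 (within the scatter), so this position can shift the reading measurably even though the two groups differ only modestly in size. Nothing available explains the direction or size of this step.

As far as these compounds go, compound 3 carries the same pair of rings but differs from compound 1 elsewhere as well, so it remains open whether this step would recur with a different group in place of the 3-hydroxyphenyl group. Also open, from the compounds shown here alone, are how the opposite arrangement at the two defined stereocentres would read and how quite different groups at this position, such as an amine, a carboxylic acid or a longer carbon chain, would compare.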